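Aryl ketone returns in place of an ester

The compounds below may be only part of what the source reports. "The series", "measured", "known", "first", "only" and "open" are said of these compounds alone.

Measured compounds:
compound 1, `N#C/C(=C\c1c(-c2ccccc2)[nH]c2ccccc12)C(=O)c1cccs1`, 6400 nM
compound 2, `COCCOC(=O)/C(C#N)=C/c1c(-c2ccccc2)[nH]c2ccccc12`, 2200 nM

In a functional assay on WIL2-NS cells (Homo sapiens) for cytotoxicity, read by MTT assay, with a stated time of 96 h (on this read-out lower numbers stand for an effect already at smaller amounts and higher numbers for an effect only at larger amounts of compound), compound 2 has the lower of the two numbers, the step of a 2.9-fold lower number from compound 1 to compound 2 (0.46 log units; beyond the scatter) lying beyond the scatter. Compound 3, `N#C/C(=C\c1c(-c2ccccc2)[nH]c2ccccc12)C(=O)c1ccc(Cl)cc1`, differs from compound 2 by 4-chlorophenyl in place of 2-methoxyethoxy on a carbonyl carbon. Among the compounds with values here, the one step that bears on this, a 2.9-fold lower number from compound 1 to compound 2 (0.46 log units; beyond the scatter), shows that replacing the thiophen-2-yl ring with 2-methoxyethoxy lowered the number; putting a 4-chlorophenyl ring back on the carbonyl carbon is therefore expected to raise it again, roughly toward compound 1, as a 2.5-fold higher number from compound 2 to compound 3 (0.40 log units; beyond the scatter). Compound 3 is expected to give about 5500 nM, within 2000 nM to 15000 nM.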

Compound 3, half-maximal effective concentration: 4500 nM
Beside the measured number, compound 3's estimate is 1.2-fold (0.09 log units) above it, within the range that was stated.
By their numbers in this assay, from the lowest: compound 2; then compounds 3 and 1 (each within the scatter of the next).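

With a 2.0-fold higher number from compound 2 to compound 3 (0.31 log units; beyond the scatter) in this assay a second aryl ring on the carbonyl carbon also ends up apart from the 2-methoxyethoxy ester, so this difference no longer rests on thiophen-2-yl alone. With a 1.4-fold lower number from compound 1 to compound 3 (0.15 log units; within the scatter) the change from thiophen-2-yl to 4-chlorophenyl does not tell these two ketones apart. No evidence on the cause is at hand. As far as these compounds go, whether an amine or a carboxylic acid on this carbonyl carbon would follow the ester or the ketones stays open. So does the reading for a longer chain in place of 2-methoxyethoxy.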